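The source may report more compounds than this note shows. Statements on the series, on what has been measured and on what is new or still open speak of the compounds shown alone.

Measured in an ADME assay on microsomes from liver (Rattus norvegicus) for metabolic stability, with a stated time of 60 min, tested at 1 uM; a higher number here means that more of the compound is left, a lower number that less of the compound is left:
- compound 1 `Cn1cc(-c2nc3c(-c4ccnc(OC5CC5)c4)cnn3cc2OCCCC(C)(C)O)cn1` gives 64%
- compound 2 `COc1cn2ncc(-c3ccnc(OC4CC4)c3)c2nc1-c1cnn(C)c1` gives 32%

Compound 2, at 32%, is the lower of the two. Compound 3 `Cn1cc(-c2nc3c(-c4ccnc(OC5CC5)c4)cnn3cc2OCC(C)(C)O)cn1` differs from it as follows: 1-hydroxy-1-methylethyl in place of hydrogen on a saturated chain carbon bound to an oxygen on an aromatic ring. Within the data shown here, one measured step bears on this: a number 32 percentage points lower from compound 1 to compound 2 (beyond the scatter), a large one, with hydrogen replacing 3-hydroxy-3-methylbutyl at that place. The new change runs the opposite way, with 1-hydroxy-1-methylethyl instead, so a rise of similar or somewhat smaller size is expected in this assay. The estimated step is a number 23 percentage points higher from compound 2 to compound 3 (beyond the scatter). For compound 3 the expected value is 55%, within 38% to 72%.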

Compound 3, percent of the compound remaining: 81%
Compound 3: the middle estimate sits 26 percentage points below what was measured, outside the stated range (above it).
By their numbers in this assay, from the lowest: compound 2; then compound 1; then compound 3.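

In this assay, 1-hydroxy-1-methylethyl in place of hydrogen gives a number 49 percentage points higher from compound 2 to compound 3 (beyond the scatter) at this saturated chain carbon, so the rise over hydrogen does not depend on the longer chain. The same group in place of 3-hydroxy-3-methylbutyl gives a number 17 percentage points higher from compound 1 to compound 3 (beyond the scatter) at this place, so the two hydroxylated chains are not interchangeable. Nothing available explains either step.

Open, as far as these compounds go, is whether the hydroxy group itself is needed, as a plain 2-methylpropyl chain would show. Also open, from the compounds shown here alone, is how an amine or a carboxylic acid on the chain would behave in this assay here.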